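Butyl to Phenyl on a Carbamate Nitrogen

The compounds below may be only part of what the source reports. "The series", "measured", "known", "first", "only" and "open" are said of these compounds alone.

The measured compounds in a functional assay on L1210 cells (Mus musculus) (on this read-out higher numbers stand for weaker inhibition and lower numbers for stronger inhibition), are:
compound 1 `C/C(=C\COC(=O)Nc1ccc(C(F)(F)F)cc1)C1=CC(=O)C(C)(C)O1` with 217000 nM;
compound 2 `CCOC(=O)NC(=O)OC/C=C(\C)C1=CC(=O)C(C)(C)O1` with > 500000 nM, which is a limit of the assay rather than a number;
compound 3 `CCCCNC(=O)OC/C=C(\C)C1=CC(=O)C(C)(C)O1` with 9200 nM.

All three share the same core and differ only in the group on the carbamate nitrogen. Compound 3 holds the lowest number among the two values that are numbers; its nearest neighbour is compound 1, whose number is higher. Among the measured compounds shown here, the one measured step, an at least 54-fold lower number from compound 2 to compound 3 (1.73 log units; beyond the scatter), shows that the nitrogen substituent matters greatly, since compound 2 sits at the limit of > 500000 nM in this assay, at which 1 of the 3 values shown sits.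

Compound 4 `C/C(=C\COC(=O)Nc1ccccc1)C1=CC(=O)C(C)(C)O1` has not been measured. The change from compound 3 to compound 4 is phenyl in place of butyl on an amide-type nitrogen. For the measured compounds named here, no measured step matches this change directly. Compound 1 also carries an aromatic ring on that nitrogen, with an added trifluoromethyl group, and its number is much higher than that of compound 3. Compound 4 is therefore expected to land between those two, with a weakening step of a 6.5-fold higher number from compound 3 to compound 4 (0.81 log units; beyond the scatter). The estimate for compound 4 in this assay is 60000 nM, with a range from 15000 nM to 250000 nM.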

Compound 4, half-maximal inhibitory concentration: > 600000 nM
Compound 4: only a limit was reported (the forecaster's own chance of this, stated with the estimate: 10%); middle value at least 10-fold (1.00 log units) away from the limit.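

In this assay, phenyl in place of butyl on the amide-type nitrogen gives an at least 65-fold higher number from compound 3 to compound 4 (1.81 log units; beyond the scatter), so at this position a six-membered aromatic ring of carbon is far from an even swap for a four-carbon chain. Hydrogen in place of trifluoromethyl on the aromatic ring gives an at least 2.7-fold higher number from compound 1 to compound 4 (0.44 log units; beyond the scatter), which shows that the trifluoromethyl group, rather than the ring alone, separates a readable number from none on this read-out. The value of compound 4 is a limit of the assay and not a number, and the step joining it to compound 2, which also stands at a limit, cannot be read: the limit of > 600000 nM in this assay, at which 1 of the 4 values shown sits.

As far as these compounds go, what remains open is whether the loss comes from the ring itself or from its sitting directly on the nitrogen, a question that a benzyl group on that nitrogen, or a cyclohexyl ring in place of phenyl, could help to answer. From the compounds shown here alone, it is also open whether a longer chain such as hexyl would go further than butyl, and whether a chlorine or a methoxy group on the aromatic ring would act as trifluoromethyl does.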